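The compounds below may be only part of what the source reports. "The series", "measured", "known", "first", "only" and "open" are said of these compounds alone.

Of the compounds shown here, three have so far been read in a functional assay on U-251 cells (Homo sapiens) for inhibition, read by sulforhodamine B assay, with a stated time of 72 h; a lower number here means that less compound is needed, a higher number that more compound is needed for the effect. Compound 1 `CC(C)(C)c1ccc(C(=O)/C=C/c2ccc([N+](=O)[O-])o2)cc1` gives 44500 nM, and compound 2 `CCCCc1ccc(C(=O)/C=C/c2ccc([N+](=O)[O-])o2)cc1` gives 3900 nM. Compound 3 `COc1ccc(/C=C/C(=O)c2cccc(Br)c2)cc1` gives 32100 nM, a number within the scatter of compound 1 and clearly higher than that of compound 2.

Compound 4 `COc1ccc(/C=C/C(=O)c2cccc(I)c2)cc1` has not yet been measured. It differs from compound 3 by iodo in place of bromo on an aromatic carbon, meta to a large group. Among the measured compounds shown here, only one measured step exists, an 11-fold lower number from compound 1 to compound 2 (1.06 log units; beyond the scatter), and it is large, but it concerns butyl in place of tert-butyl on the core of compound 1. For the measured compounds named here, it shows that one exchange can matter in this assay, yet it gives no direction for an exchange of one halogen for another, and no measured step covers such a change. The expected result is therefore no step beyond the scatter, with a 1.1-fold lower number from compound 3 to compound 4 (0.06 log units; within the scatter) as the estimated size. For compound 4 the estimated value is 28000 nM, with an expected range from 12000 nM to 60000 nM.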

Compound 4, half-maximal effective concentration: 21400 nM
The estimate for compound 4 lay 1.3-fold (0.12 log units) above the measured number, within the range that was stated.
By their numbers in this assay, from the lowest: compound 2; then compounds 4, 3 and 1 (each within the scatter of the next, the first and the last beyond it).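

In this assay, iodo in place of bromo on an aromatic carbon, meta to a large group, gives a 1.5-fold lower number from compound 3 to compound 4 (0.18 log units; within the scatter), so this exchange of one halogen for another stays within the scatter. Among the compounds shown here, that sets it apart from the only earlier step, an 11-fold lower number from compound 1 to compound 2 (1.06 log units; beyond the scatter), which concerned butyl in place of tert-butyl and lay beyond the scatter. No measurement is available that would explain the result.

The compounds shown leave open whether a smaller halogen such as fluoro, or a different group such as an amine or a carboxylic acid, would stay within the scatter at this place. They also leave open whether a longer chain in place of the methoxy group on the other ring of compound 3 would change the number more than this halogen exchange does.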